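Working notes on a small series: three measured, one pending

This account rests on a few compounds, and the source may have more. Where it says the series, first, only, none or still open, it means among the compounds named here.

Measured so far:
compound 1 `COc1cccc(C2CCc3nc[nH]c3C2)c1` — > 10000 nM
compound 2 `c1ccc(C2CCc3nc[nH]c3C2)cc1` — > 10000 nM; > 10000 nM; > 10000 nM (3 entries)
compound 3 `Clc1ccc(C2Cc3nccn3C2)cc1` — > 10000 nM

In a functional assay on CHO cells for agonist activity at Alpha-1B adrenergic receptor (Homo sapiens), read by FLIPR and calcium flux (a lower number here means that less compound is needed, a higher number that more compound is needed for the effect), compound 1 gives > 10000 nM, which is a limit of the assay and not a number. Compound 2 gives > 10000 nM; > 10000 nM; > 10000 nM (3 entries) across three entries, each a limit. Compound 3 gives > 10000 nM, also a limit. Compound 1 therefore stands nowhere distinct on the numbers shown: all entries sit at the limit of > 10000 nM in this assay, at which 2 of the 3 values shown sit, and no compound here separates from another.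

Compound 4 `Clc1cccc(C2CCc3nc[nH]c3C2)c1` is not yet measured. It differs from compound 1 by chloro in place of methoxy on an aromatic carbon. Going by the values given here, no step between measured compounds exists, so there is nothing to set a size or direction against; with every value at the limit, the expected step from compound 1 to compound 4 is a step that the limit leaves unreadable from compound 1 to compound 4, none beyond the scatter. Compound 4 is estimated at 20000 nM, with a range from 5000 nM to 80000 nM, most likely again reported only as a limit.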

Compound 4, half-maximal effective concentration in the Alpha-1B adrenergic receptor assay: > 10000 nM
Compound 4 gave a limit, no number; the forecaster's own chance of this, stated with the estimate: 85%; the middle value is on the limit's open side.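

In the Alpha-1B adrenergic receptor assay compound 1 gives > 10000 nM, which is a limit and not a number. In the Alpha-1B adrenergic receptor assay compound 4 gives > 10000 nM, which is also a limit. The step between these two compounds therefore cannot be read. In a physicochemical assay for lipophilicity, at pH 7.4 (on this read-out lower numbers stand for lower lipophilicity and higher numbers for higher lipophilicity), compound 1 gives 2.6 and compound 4 gives 3.3. As far as these compounds go, whether any change to the shared core gives a readable value in the Alpha-1B adrenergic receptor assay remains open.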